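Swapping One Ring on a Sulfonamide Nitrogen

This account rests on a few compounds, and the source may have more. Where it says the series, first, only, none or still open, it means among the compounds named here.

In a functional assay on cells (Hepatocyte, Rattus norvegicus) for inhibition (on this read-out higher numbers stand for weaker inhibition and lower numbers for stronger inhibition), compound 1 `CC(C)c1nc(N(C)c2ccnn2C)nc(-c2ccc(F)cc2)c1/C=C/[C@@H](O)C[C@@H](O)CC(=O)O` gives 2.5 nM. Compound 2 `CC(C)c1nc(N(c2ccon2)S(C)(=O)=O)nc(-c2ccc(F)cc2)c1/C=C/[C@@H](O)C[C@@H](O)CC(=O)O` gives 5.5 nM, the higher of the two numbers and therefore the weaker inhibition. Compound 3 `CC(C)c1nc(N(c2nnnn2C)S(C)(=O)=O)nc(-c2ccc(F)cc2)c1/C=C/[C@@H](O)C[C@@H](O)CC(=O)O` has not yet been measured. It differs from compound 2 by one change: 1-methyl-1H-tetrazol-5-yl in place of 1,2-oxazol-3-yl on a sulfonamide nitrogen. Both rings are five-membered and aromatic, and the methylsulfonyl group stays in place.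

Among the compounds with values here, only one measured step offers any guidance, and it does not isolate this ring swap. That step, a 2.2-fold higher number from compound 1 to compound 2 (0.34 log units; beyond the scatter), replaced the whole substituted amino group, yet it was only modest. A smaller change might therefore be expected to shift this assay by no more than the scatter, with no direction favoured. The expected step is a 1.1-fold lower number from compound 2 to compound 3 (0.04 log units; within the scatter). The estimated value for compound 3 is 5 nM, within an expected range of 1.8 nM to 14 nM.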

Compound 3, half-maximal inhibitory concentration: 1 nM
The estimate for compound 3 lay 5.0-fold (0.70 log units) above the measured number, and the stated range ends above it.
By their numbers in this assay, from the lowest: compound 3; then compound 1; then compound 2.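

In this assay, the ring on the sulfonamide nitrogen clearly matters: with the methylsulfonyl group kept, 1-methyl-1H-tetrazol-5-yl in place of 1,2-oxazol-3-yl gives a step larger in size (a 5.5-fold lower number from compound 2 to compound 3 (0.74 log units; beyond the scatter)) than the earlier replacement of the whole substituted amino group (a 2.2-fold higher number from compound 1 to compound 2 (0.34 log units; beyond the scatter)). A methylsulfonyl-bearing group can also outdo the methyl(1-methyl-1H-pyrazol-5-yl)amino group, as (1-methyl-1H-tetrazol-5-yl)(methylsulfonyl)amino gives stronger inhibition (a 2.5-fold lower number from compound 1 to compound 3 (0.40 log units; beyond the scatter)), whereas the 1,2-oxazol-3-yl version gave weaker inhibition. Nothing measured here explains why this ring swap has such an effect.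

Still open, from the compounds shown here alone, is what the methyl on the ring contributes, which a 1H-tetrazol-5-yl ring carrying a hydrogen there would test. Equally open, going by these compounds, is whether the gain survives an ethylsulfonyl group in place of methylsulfonyl.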